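This account rests on a few compounds, and the source may have more. Where it says the series, first, only, none or still open, it means among the compounds named here.

Measured so far in an assay on HEK293 cells for negative allosteric modulation of metabotropic glutamate receptor 5 (Homo sapiens), read by FLIPR, with a stated time of 1 h; on this read-out lower numbers stand for stronger inhibition and higher numbers for weaker inhibition:
compound 1, `Fc1cccc(C#Cc2nc3c(s2)CN(C2CCOC2)CC3)c1`, 400 nM
compound 2, `CC1CC1C(=O)N1CCc2nc(C#Cc3ccccc3)sc2C1`, > 10000 nM
compound 3, `O=S(=O)(C1CCCCC1)N1Cc2nc(C#Cc3ccccc3)sc2C1`, > 10000 nM

The three compounds share a core, and in this assay compound 1 gives 400 nM. Compound 2 reaches only > 10000 nM, which is a limit of this assay and not a number. Compound 3 likewise stops at a limit, > 10000 nM. Within the data shown here, compound 2 therefore stands at the limit of > 10000 nM in this assay, at which 2 of the 3 values shown sit, and no measured step to another compound is available for it, since no pair of measured compounds differs in a single place.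

The next compound, compound 4, `O=C(N1CCC(F)CC1)N1CCc2nc(C#Cc3ccccc3)sc2C1`, differs from compound 2 in one spot: 4-fluoropiperidin-1-yl in place of 2-methylcyclopropyl on a carbonyl carbon. Because compound 2 already sits at the limit, as shown by the limit of > 10000 nM in this assay, at which 2 of the 3 values shown sit, there is no measured number from which a step could be counted, and nothing among the measured compounds points to a change beyond the usual scatter. The expected step is a number no higher from compound 2 to compound 4 (the limit leaves the size open). Compound 4 is accordingly estimated at 10000 nM in this assay, with an expected range from 3000 nM to 30000 nM, and it is quite likely to be reported as a limit again rather than as a number.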

Compound 4, half-maximal inhibitory concentration: > 10000 nM
Compound 4: only a limit was reported (the forecaster's own chance of this, stated with the estimate: 70%); the middle value sits exactly at the limit.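

In this assay compound 4 gives > 10000 nM, which is a limit and not a number. Compound 2 also stands at a limit, so no step can be read from compound 2 to compound 4: the limit of > 10000 nM in this assay, at which 3 of the 4 values shown sit.

The compounds shown leave open how 4-fluoropiperidin-1-yl and 2-methylcyclopropyl on a carbonyl carbon compare in this read-out.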